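Adding a Chloro Group to a Methylated Urea Analog

A few compounds are considered here, and "the series" means these few. Any claim that something is new, unique, unknown or untested is made for them only; others in the source may bear on it.

Compound 1 `O=C(Nc1ccccc1)Nc1cccc(CNc2nccnc2Cl)c1` is the starting point of this small series. In a functional assay on T-24 cells (Homo sapiens) for antiproliferative activity, read by MTT assay, with a stated time of 48 h (on this read-out lower numbers stand for stronger inhibition and higher numbers for weaker inhibition), compound 1 gives 19800 nM. Compound 2 `O=C(Nc1cccc(Cl)c1)Nc1cccc(CNc2nccnc2Cl)c1` carries chloro in place of hydrogen on an aromatic carbon, and in this assay compound 2 gives 6810 nM, a step of a 2.9-fold lower number from compound 1 to compound 2 (0.46 log units; beyond the scatter). Compound 3 `Cc1ccc(NC(=O)Nc2cccc(CNc3nccnc3Cl)c2)cc1` differs from compound 1 by methyl in place of hydrogen on an aromatic carbon; in this assay compound 3 gives 9820 nM, with a 2.0-fold lower number from compound 1 to compound 3 (0.30 log units; within the scatter) and a 1.4-fold higher number from compound 2 to compound 3 (0.16 log units; within the scatter) both within the scatter. Compound 4 `Cc1ccc(NC(=O)Nc2cccc(CNc3nccnc3Cl)c2)cc1Cl` has not yet been measured in this assay. It differs from compound 3 by chloro in place of hydrogen on an aromatic carbon. This is the same kind of change as that from compound 1 to compound 2, but here the entering chloro is ortho to a methyl group as well as meta to a large group. Because a 2.9-fold lower number from compound 1 to compound 2 (0.46 log units; beyond the scatter) lay beyond the scatter, a step of similar size is expected for compound 4, a 2.6-fold lower number from compound 3 to compound 4 (0.41 log units; beyond the scatter). Compound 4 is therefore estimated at 3800 nM, between 1500 nM and 9500 nM.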

Compound 4, half-maximal inhibitory concentration: 7390 nM
Compound 4: the middle estimate sits 1.9-fold (0.29 log units) below what was measured; measured number inside the range.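

In this assay the chloro change gives a 1.3-fold lower number from compound 3 to compound 4 (0.12 log units; within the scatter), and this does not differ measurably from the same change on the core of compound 1: the same change on two cores in this assay, a 2.9-fold lower number (0.46 log units; beyond the scatter) from compound 1 to compound 2 and a 1.3-fold lower number (0.12 log units; within the scatter) from compound 3 to compound 4, 2.2-fold (0.34 log units) apart, within the scatter of two such steps. The methyl change, read on the chlorinated core, gives a 1.1-fold higher number from compound 2 to compound 4 (0.04 log units; within the scatter), and it likewise does not differ measurably from its earlier counterpart: the same change on two cores in this assay, a 2.0-fold lower number (0.30 log units; within the scatter) from compound 1 to compound 3 and a 1.1-fold higher number (0.04 log units; within the scatter) from compound 2 to compound 4, 2.2-fold (0.34 log units) apart, within the scatter of two such steps. Both changes together give a 2.7-fold lower number from compound 1 to compound 4 (0.43 log units; beyond the scatter), yet agreement within the scatter does not show that either change keeps its size from one core to another.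

From the compounds shown here alone, it remains open how a fluoro or methoxy group in place of the chloro would behave. Going by these compounds, the effect of an amine or a carboxylic acid on the same aromatic ring also remains open.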